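Moving the fluorine on the aryl ring of an ethyl analogue

A few compounds are considered here, and "the series" means these few. Any claim that something is new, unique, unknown or untested is made for them only; others in the source may bear on it.

Measured so far:
Compound 1 `Cc1nc(-c2ccc(F)cc2)c(C(=O)N2CCN(c3cccc(Cl)c3)CC2)o1`: 40.1 nM
Compound 2 `Cc1nc(-c2cccc(F)c2)c(C(=O)N2CCN(c3cccc(Cl)c3)CC2)o1`: 33.7 nM
Compound 3 `CCc1nc(-c2cccc(F)c2)c(C(=O)N2CCN(c3cccc(OC)c3)CC2)o1`: 201 nM

All three were tested in a functional assay on HL-60 cells (Homo sapiens) for inhibition, read by MTT assay, with a stated time of 72 h; on this read-out lower numbers stand for stronger inhibition and higher numbers for weaker inhibition. Compound 1 and compound 2 differ only in where the fluorine sits: 4-fluorophenyl in place of 3-fluorophenyl on an aromatic carbon. That change gave a 1.2-fold higher number from compound 2 to compound 1 (0.08 log units; within the scatter). Compound 3 gives a number beyond the scatter above both, yet the difference between its core and that of compound 2 is not broken down here.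

Compound 4 `CCc1nc(-c2ccc(F)cc2)c(C(=O)N2CCN(c3cccc(OC)c3)CC2)o1` is not yet measured. It relates to compound 3 as compound 1 does to compound 2: 4-fluorophenyl in place of 3-fluorophenyl on an aromatic carbon. The surroundings are the same kind, not the same: in compound 3 the ring atom two ring bonds away bears an ethyl group, whereas in compound 2 it bears a methyl group. Because a 1.2-fold higher number from compound 2 to compound 1 (0.08 log units; within the scatter) was within the scatter, a similarly small step is expected here, a 1.2-fold higher number from compound 3 to compound 4 (0.08 log units; within the scatter), starting from compound 3 at 201 nM. Compound 4 is therefore estimated at 240 nM, between 100 nM and 560 nM.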

Compound 4, half-maximal inhibitory concentration: 411 nM
Compound 4: the middle estimate sits 1.7-fold (0.23 log units) below what was measured, within the range that was stated.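

Placing 4-fluorophenyl where 3-fluorophenyl stood gave a 2.0-fold higher number from compound 3 to compound 4 (0.31 log units; beyond the scatter). Only this new step lies beyond the scatter, yet the two steps cannot be told apart: the same change on two cores in this assay, a 1.2-fold higher number (0.08 log units; within the scatter) from compound 2 to compound 1 and a 2.0-fold higher number (0.31 log units; beyond the scatter) from compound 3 to compound 4, 1.7-fold (0.24 log units) apart, within the scatter of two such steps

Across these two cores, then, the change stays a small step, and the earlier result carried over reasonably well. Two cores cannot show whether the core truly alters the size of the step, or how the change would behave on any other core.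

The compounds shown leave open what a nitrile or a trifluoromethyl group would do in place of the fluorine. They also leave open whether a chain longer than ethyl would alter the step.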